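The source may hold more compounds than are shown below. What is called first, only, known or untested is meant among the compounds shown, and "the series" means these compounds.

In a functional assay on SK-MEL-5 cells (Homo sapiens) for cytotoxicity (on this read-out lower numbers stand for an effect already at smaller amounts and higher numbers for an effect only at larger amounts of compound), compound 1 `COc1ccc(/C=C/c2cc(OC)c(OC(C)=O)c(OC)c2)cc1`, which has an acetyl on an oxygen on an aromatic ring, gives 10.2 uM. Compound 2 `COc1ccc(/C=C/c2cc(OC)c(OCc3ccccc3)c(OC)c2)cc1` has benzyl in that place and reaches only a limit of the assay, > 25 uM. Compound 2 therefore stands at the limit of > 25 uM in this assay, at which 1 of the 3 values shown sits, and no number is available for it. For the measured compounds named here, the one measured step is an at least 2.4-fold higher number from compound 1 to compound 2 (0.38 log units; beyond the scatter), and it concerns the group on the oxygen, not the double bond.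

Compound 4 `COc1ccc(/C=C\c2cc(OC)c(OCc3ccccc3)c(OC)c2)cc1` is the next case, and its relation to compound 2 is simple: the two compounds have the same atoms and bonds and differ only in configuration as drawn: 1 of 1 stereo elements differ; a double bond is drawn E in compound 2 and Z in compound 4. Going by the values given here, no measured step covers a change of this kind, so the step above gives no direct guide to its size. Among the compounds with values here, compound 3 `COc1cc(/C=C\c2ccc(C(C)C)cc2)cc(OC)c1OC` is the only measured compound with its double bond drawn Z, and in this assay compound 3 gives 4.7 uM, which is the sole ground for expecting a shift toward a lower number. Within the data shown here, no measured pair isolates that configuration, so this ground is weak, and another result at the limit remains possible. The expected change is an at least 2.0-fold lower number from compound 2 to compound 4 (0.31 log units; beyond the scatter). For compound 4 the estimate is 12 uM, with an expected range from 4 uM to 30 uM.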

Compound 4, concentration for half-maximal effect: 6.1 uM
Estimate against measurement, compound 4: 2.0-fold (0.29 log units) above; the range from low to high includes it.
By their numbers in this assay, from the lowest: compounds 3, 4 and 1 (each within the scatter of the next, the first and the last beyond it). At a limit, above all of these: compound 2.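

In this assay the configuration of the double bond now has a measured step of its own, an at least 4.0-fold lower number from compound 2 to compound 4 (0.61 log units; beyond the scatter), and this step can be laid on the double bond alone because of this: the fact that compounds 2 and 4 differ only in the configuration as drawn. As far as these compounds go, the value of compound 2 is a limit and not a number, so the step gives only a smallest size and its full size stays unknown: the limit of > 25 uM in this assay, at which 1 of the 4 values shown sits. The earlier compounds shown here showed benzyl on the oxygen only with the double bond drawn E, whereas with the benzyl kept and the double bond drawn Z, compound 4 gives 6.1 uM. The result at the limit for compound 2 therefore does not go with benzyl in this place by itself.

The compounds shown leave open whether the acetyl of compound 1 would show a shift of the same direction and size with the double bond drawn Z, since the step is known only with benzyl on that oxygen. They also leave open how a free hydroxyl, a longer chain such as butyl or an aminoethyl group on that oxygen would read with either configuration of the double bond.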